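The compounds below may be only part of what the source reports. "The series", "measured", "known", "first", "only" and "open" are said of these compounds alone.

Compound 1, `C/C=C(\C)C(=O)O[C@@H]1[C@@H]2OC[C@]3(C)[C@H](OC(C)=O)C[C@H](OC(=O)/C(C)=C/C)[C@@](C)([C@@H]23)[C@H]2CC(=O)O[C@H]3C[C@@H](c4ccoc4)C(C)=C3[C@]12C`: 33800 nM
Compound 2, `C/C=C(\C)C(=O)O[C@@H]1[C@@H]2OC[C@]3(C)[C@H](OC(C)=O)C[C@H](OC(=O)c4ccccc4)[C@@](C)([C@@H]23)[C@H]2CC(=O)O[C@H]3C[C@@H](c4ccoc4)C(C)=C3[C@]12C`: 33000 nM

In a functional assay on HeLa S3 cells (Homo sapiens) for cytotoxicity, read by WST assay, with a stated time of 72 h (a higher number here means a weaker inhibitor, a lower number a stronger inhibitor), compound 1 gives 33800 nM, and compound 2 gives 33000 nM. The two numbers sit within the scatter of each other, as the step of a 1.0-fold lower number from compound 1 to compound 2 (0.01 log units; within the scatter) shows; compound 2 is therefore not set apart from compound 1 on these numbers.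

Compound 3, `C/C=C(\C)C(=O)O[C@@H]1[C@@H]2OC[C@]3(C)[C@H](OC(C)=O)C[C@H](O)[C@@](C)([C@@H]23)[C@H]2CC(=O)O[C@H]3C[C@@H](c4ccoc4)C(C)=C3[C@]12C`, differs from compound 2 by hydrogen in place of benzoyl on an oxygen on a saturated carbon. For the measured compounds named here, the only measured step, a 1.0-fold lower number from compound 1 to compound 2 (0.01 log units; within the scatter), exchanged one acyl group for another on the same oxygen and left the number unchanged. Stripping the acyl away to leave a hydroxy is a different kind of change, so that step bears on it only loosely. With nothing showing that this oxygen's substituent matters, compound 3 is expected to stay near compound 2, with a 1.1-fold higher number from compound 2 to compound 3 (0.03 log units; within the scatter). The estimate for compound 3 in this assay is 35000 nM, within 12000 nM to 100000 nM.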

Compound 3, half-maximal inhibitory concentration: 100 nM
Beside the measured number, compound 3's estimate is 350-fold (2.54 log units) above it; the whole stated range lies above it.
By their numbers in this assay, from the lowest: compound 3; then compounds 2 and 1 (each within the scatter of the next).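

In this assay, the oxygen on a saturated carbon proves highly sensitive to what it carries, although exchanging one acyl group for another there had left the number unchanged. Removing the acyl altogether gives a 330-fold lower number from compound 2 to compound 3 (2.52 log units; beyond the scatter) when benzoyl leaves and a 340-fold lower number from compound 1 to compound 3 (2.53 log units; beyond the scatter) when (1-methylprop-1-en-1-yl)carbonyl leaves. Across these three compounds, the divide therefore lies between the free hydroxy and either acyl group, not between the two acyl groups, and no supporting measurement accounts for it.

From the compounds shown here alone, it remains open whether the hydroxy itself is required, since a methyl ether or an amine in its place would test this. A formyl group on this oxygen would show whether a much smaller acyl group behaves like benzoyl or like hydrogen.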